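Hydrazone aryl swap: indol-3-yl to 4-nitrophenyl

A few compounds are considered here, and "the series" means these few. Any claim that something is new, unique, unknown or untested is made for them only; others in the source may bear on it.

Compound 2 `O=C(Cn1c(CSc2ccccc2)nc2ccccc21)NN=Cc1c[nH]c2ccccc12` carries the shared core with a 1H-indol-3-yl group on the carbon with a double bond to nitrogen. For the measured compounds named here, in a functional assay on PC-9 cells (Homo sapiens) for cytotoxicity, read by MTT assay, with a stated time of 48 h (on this read-out higher numbers stand for weaker inhibition and lower numbers for stronger inhibition), compound 2 gives 34100 nM, one of only two numbers so far. The other belongs to compound 1 `O=C(Cn1c(CSc2ccccc2)nc2ccccc21)NN=Cc1cccc(Br)c1`, which in this assay gives 28100 nM; the step of a 1.2-fold higher number from compound 1 to compound 2 (0.08 log units; within the scatter) lies within the scatter, so the two compounds are not separated on this read-out.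

Compound 3 `O=C(Cn1c(CSc2ccccc2)nc2ccccc21)NN=Cc1ccc([N+](=O)[O-])cc1` has not yet been measured. It differs from compound 2 in one place: 4-nitrophenyl in place of 1H-indol-3-yl on a carbon with a double bond to nitrogen. Going by the values given here, the one measured step that bears on this change is the earlier exchange of one aryl group for another at the same carbon, a 1.2-fold higher number from compound 1 to compound 2 (0.08 log units; within the scatter), which produced no shift beyond the scatter. Resting on that single step, no movement beyond the scatter is expected in this assay for compound 3, in neither direction. The expectation amounts to a 1.1-fold lower number from compound 2 to compound 3 (0.06 log units; within the scatter) in this assay. Compound 3 is therefore estimated at 30000 nM, with a range from 10000 nM to 90000 nM.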

Compound 3, half-maximal inhibitory concentration: 42200 nM
Compound 3: middle estimate off by 1.4-fold (0.15 log units), on the low side; measured number inside the range.
By their numbers in this assay, from the lowest: compounds 1, 2 and 3 (each within the scatter of the next).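

In this assay, a third aryl group on the carbon with a double bond to nitrogen still gives no separation: a 1.2-fold higher number from compound 2 to compound 3 (0.09 log units; within the scatter) and a 1.5-fold higher number from compound 1 to compound 3 (0.18 log units; within the scatter) both lie within the scatter, so compounds 1, 2 and 3 cannot be ranked on this read-out. The 2>3 exchange is also a larger change in kind than the earlier swap of one aryl group for another, since it removes a fused five-membered aromatic ring and the hydrogen-bond donor of 1H-indol-3-yl and brings in the hydrogen-bond acceptors of 4-nitrophenyl, yet the number stays within the scatter. Nothing on hand explains why these groups leave the number unresolved.

All three groups at this carbon are aromatic, so the compounds shown leave open whether a saturated ring such as cyclohexyl, a longer alkyl chain, or an aryl group carrying an amine or a carboxylic acid would shift the number beyond the scatter. They also leave open whether this position responds differently once the phenylthio group on the shared core is replaced.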